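The compounds below may be only part of what the source reports. "The series", "measured", "known", "first", "only" and "open" are said of these compounds alone.

In a functional assay on DU-145 cells (Homo sapiens) for inhibition, read by MTT assay, with a stated time of 2 days (on this read-out lower numbers stand for stronger inhibition of growth and higher numbers for weaker inhibition of growth), compound 1 `O=C(Nn1c(-c2cccc([N+](=O)[O-])c2)nc2c(-c3ccc(Cl)cc3)n[nH]c2c1=O)c1ccccc1` gives 17100 nM, compound 2 `O=C(Nn1c(-c2ccccc2)nc2c(-c3ccc(Cl)cc3)n[nH]c2c1=O)c1ccccc1` gives 20100 nM and compound 3 `CCCCc1nc2c(-c3ccc(Cl)cc3)n[nH]c2c(=O)n1NC(=O)c1ccccc1` gives 29100 nM. Compound 3 carries the highest of the three numbers, yet its separation from the others is slight: a 1.7-fold higher number from compound 1 to compound 3 (0.23 log units; within the scatter) and a 1.4-fold higher number from compound 2 to compound 3 (0.16 log units; within the scatter), and a 1.2-fold higher number from compound 1 to compound 2 (0.07 log units; within the scatter) is equally slight. Compound 4 `CCCCCc1nc2c(-c3ccc(Cl)cc3)n[nH]c2c(=O)n1NC(=O)c1ccccc1` differs from compound 3 by methyl in place of hydrogen on a saturated chain carbon, four bonds along the chain from an aromatic carbon. Among the measured compounds shown here, no measured step lengthens a chain, so none bears directly on this change; the three steps that exist all sit within the scatter, and nothing points to a shift beyond the scatter in this assay. For compound 4 the expected step is a 1.0-fold higher number from compound 3 to compound 4 (0.01 log units; within the scatter). The estimate for compound 4 in this assay is 30000 nM, with a range from 12000 nM to 75000 nM.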

Compound 4, concentration for 50% growth inhibition: 22100 nM
The estimate for compound 4 lay 1.4-fold (0.13 log units) above the measured number; the range from low to high includes it.
By their numbers in this assay, from the lowest: compounds 1, 2, 4 and 3 (each within the scatter of the next).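

In this assay, among the compounds shown here, methyl in place of hydrogen on a saturated chain carbon, four bonds along the chain from an aromatic carbon, gives a 1.3-fold lower number from compound 3 to compound 4 (0.12 log units; within the scatter), the first reading on chain length at this position. Pentyl also stays level with the aromatic groups, with a 1.1-fold higher number from compound 2 to compound 4 (0.04 log units; within the scatter) for phenyl and a 1.3-fold higher number from compound 1 to compound 4 (0.11 log units; within the scatter) for 3-nitrophenyl, so neither the chain nor the aromatic groups are told apart here. No supporting evidence bears on this result.

On these data alone, whether a longer chain such as decyl, or an amine or carboxylic acid at the chain end, would move the number beyond the scatter remains open.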